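Azetidinyl urea in place of cyclopentyl amide on the piperidine nitrogen

A few compounds are considered here, and "the series" means these few. Any claim that something is new, unique, unknown or untested is made for them only; others in the source may bear on it.

Measured so far:
- compound 1, `CCN(CC)S(=O)(=O)c1ccc(NC(=O)c2ccccc2)c2ccccc12`: > 30000 nM
- compound 2, `CCOC(=O)N1CCC(NS(=O)(=O)c2ccc(NCc3ccccc3)c3ccccc23)CC1`: 45.6 nM
- compound 3, `Cc1ccccc1C(=O)Nc1ccc(S(=O)(=O)NC2CCN(C(=O)C3CCCC3)CC2)c2ccccc12`: 9.1 nM

In an assay on L1.2 cells for binding affinity to C-C chemokine receptor type 8 (Homo sapiens) (on this read-out higher numbers stand for weaker inhibition and lower numbers for stronger inhibition), compound 1 reaches only a limit, > 30000 nM; the limit is marked as such in the limit of > 30000 nM in this assay, at which 1 of the 3 values shown sits, and gives no number. Compound 2 gives 45.6 nM in this assay. Compound 3 gives 9.1 nM, the lowest of the two numbers shown, and it sits well beyond the scatter from compound 2. Among the compounds with values here, compound 1 and compound 2 differ from compound 3 in more than one place, so no single step between measured compounds can be read off.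

Compound 4, `Cc1ccccc1C(=O)Nc1ccc(S(=O)(=O)NC2CCN(C(=O)N3CCC3)CC2)c2ccccc12`, differs from compound 3 at the carbonyl on the amide-type nitrogen in a ring: azetidin-1-yl in place of cyclopentyl on a carbonyl carbon. The change keeps the carbonyl and swaps one small saturated ring for another of near size. Compound 2, with an ethyl carbamate at the same nitrogen, still gives a low number, so the group at this position appears tolerated, though compound 2 also differs elsewhere. The step from compound 3 to compound 4 is therefore expected to be small, a 1.5-fold higher number from compound 3 to compound 4 (0.19 log units; within the scatter), most likely within the scatter or a slight weakening. Compound 4 is estimated at 14 nM, between 5 nM and 45 nM.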

Compound 4, inhibition constant: 3.5 nM
The estimate for compound 4 lay 4.0-fold (0.60 log units) above the measured number; measured number below the stated range.
By their numbers in this assay, from the lowest: compound 4; then compound 3; then compound 2. At a limit, above all of these: compound 1.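

In this assay, azetidin-1-yl in place of cyclopentyl on a carbonyl carbon gives a 2.6-fold lower number from compound 3 to compound 4 (0.41 log units; beyond the scatter), so the number at this position responds to the group carried there. Within the data shown here, as the first single-place step, it shows that a four-membered ring with a hetero atom is accepted in place of a five-membered ring of carbon only, with the number going down. Nothing measured here accounts for the size of this step.

The compounds shown do not separate the change in ring size from the entry of the ring nitrogen, a question that cyclobutyl or pyrrolidin-1-yl on the same carbonyl carbon would address. Also open, on these data alone, is how an open-chain group such as dimethylamino reads at this position.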